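The source may hold more compounds than are shown below. What is called first, only, known or untested is meant among the compounds shown, and "the series" means these compounds.

In a physicochemical assay for solubility, measured as kinetic solubility (a higher number here means a more soluble compound, a lower number a less soluble compound), compound 1 `CNC(=O)c1cc(C(=O)N[C@H]2CC[C@H](O)CC2)n([C@@H](C)c2cccc(Cl)c2)n1` stands at >= 143 ug/mL, and this value is a limit. Compound 3 `CNC(=O)c1cc(C(=O)N[C@H]2CC[C@H](O)CC2)n([C@@H](C)c2ccccc2Cl)n1` gives >= 182 ug/mL, also a limit. Compound 2 `CNC(=O)c1cc(C(=O)N[C@H]2CC[C@H](O)CC2)n([C@@H](C)c2cccc(C(F)(F)F)c2)n1` gives a true number, 7 ug/mL. Compound 4 `CNC(=O)c1cc(C(=O)N[C@H]2[C@@H]3C[C@@H](O)C[C@@H]32)n([C@@H](C)c2cccc(Cl)c2)n1` keeps the core of compound 1 and changes only the group on the amide-type nitrogen: a group of 7 heavy atoms (6 carbon, 1 oxygen; one three-membered non-aromatic ring of carbon only, one five-membered non-aromatic ring of carbon only) in place of a group of 7 heavy atoms (6 carbon, 1 oxygen; one six-membered non-aromatic ring of carbon only), on an amide-type nitrogen. The measured steps, an at least 20-fold lower number from compound 1 to compound 2 (1.31 log units; beyond the scatter) and an at least 26-fold higher number from compound 2 to compound 3 (1.41 log units; beyond the scatter), both large, together with a step that the two limits leave unreadable from compound 1 to compound 3, alter only the aromatic group, so they give no direct measure of this change, and no step beyond the scatter is expected. The expected change is a step that the limit leaves unreadable from compound 1 to compound 4. For compound 4 the estimate is 150 ug/mL, with an expected range from 60 ug/mL to 260 ug/mL.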

Compound 4, solubility: 175 ug/mL
Compound 4: middle estimate off by 1.2-fold (0.07 log units), on the low side, within the range that was stated.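

No step can be read from compound 1 to compound 4 in this assay, because compound 1 stands only at a limit: the limit of >= 143 ug/mL in this assay, at which 1 of the 4 values shown sits. The compounds shown leave open whether replacing 4-hydroxycyclohexyl on the amide-type nitrogen changes the number in this assay at all.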